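Swapping a Nitrophenyl Arm for a Bromophenyl One

This account rests on a few compounds, and the source may have more. Where it says the series, first, only, none or still open, it means among the compounds named here.

Three compounds sharing one core were measured in a functional assay on MDA-MB-231 cells (Homo sapiens) for inhibition, read by MTT assay, with a stated time of 72 h; a higher number here means a weaker inhibitor, a lower number a stronger inhibitor. Compound 1 `C=CC(=O)Nc1cccc(NC(=O)CSc2nc(Nc3ccccc3C)c3ccccc3n2)c1` gives 20400 nM, and compound 2 `C=CC(=O)Nc1cccc(NC(=O)CSc2nc(Nc3cccc(F)c3)c3ccccc3n2)c1` gives 8160 nM, a step of a 2.5-fold lower number from compound 1 to compound 2 (0.40 log units; beyond the scatter). Compound 3 `C=CC(=O)Nc1cccc(NC(=O)CSc2nc(Nc3cccc([N+](=O)[O-])c3)c3ccccc3n2)c1` reaches only (the limit of > 50000 nM in this assay, at which 1 of the 3 values shown sits), so for compound 3 > 50000 nM is a limit rather than a number. That leaves compound 3 the weakest of the three, with steps of an at least 2.4-fold higher number from compound 1 to compound 3 (0.38 log units; beyond the scatter) and an at least 6.1-fold higher number from compound 2 to compound 3 (0.78 log units; beyond the scatter). Compound 4 `C=CC(=O)Nc1cccc(NC(=O)CSc2nc(Nc3ccc(Br)cc3)c3ccccc3n2)c1` differs from compound 3 by 4-bromophenyl in place of 3-nitrophenyl on a nitrogen on an aromatic ring. The two steps into compound 3, both at least modest, bear on it, and compound 2 with its fluoro gave the lowest number, 8160 nM. Compound 4 is therefore expected to fall back toward a measurable number, with an at least 3.3-fold lower number from compound 3 to compound 4 (0.52 log units; beyond the scatter). The estimate for compound 4 is 15000 nM, within 5000 nM to 50000 nM.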

Compound 4, half-maximal inhibitory concentration: 17300 nM
Compound 4: middle estimate off by 1.2-fold (0.06 log units), on the low side; low and high end bracket the measured number.
By their numbers in this assay, from the lowest: compound 2; then compounds 4 and 1 (each within the scatter of the next). At a limit, above all of these: compound 3.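

In this assay, 4-bromophenyl on this nitrogen brings the series back to a measurable number, with an at least 2.8-fold lower number from compound 3 to compound 4 (0.46 log units; beyond the scatter), and the size of that step is only bounded: the limit of > 50000 nM in this assay, at which 1 of the 4 values shown sits. Set against 2-methylphenyl, 4-bromophenyl gives a 1.2-fold lower number from compound 1 to compound 4 (0.07 log units; within the scatter), so these two arms cannot be told apart here. Set against 3-fluorophenyl, it gives a 2.1-fold higher number from compound 2 to compound 4 (0.33 log units; beyond the scatter), so 3-fluorophenyl keeps a modest lead.

On these data alone, what a 3-bromophenyl or 4-nitrophenyl arm would give remains open, so the group and its place on the ring cannot be separated. As far as these compounds go, how an amine or a carboxylic acid on this arm would read is also open.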